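Hydroxy in place of hydrogen on the anilino ring: compound 4

The source may hold more compounds than are shown below. What is called first, only, known or untested is meant among the compounds shown, and "the series" means these compounds.

Compound 1 `Fc1cccc(-c2nc(Nc3ccccc3)c3cc(F)ccc3n2)c1` gives 47800 nM in a functional assay on MDA-MB-231 cells (Homo sapiens) for cytotoxicity, read by MTT assay, with a stated time of 48 h; a lower number here means a stronger inhibitor, a higher number a weaker inhibitor.
Compound 2 `COc1ccc(Nc2nc(-c3cccc(F)c3)nc3ccc(F)cc23)cc1` gives 47300 nM in this assay.
Compound 3 `Oc1ccc(Nc2nc(-c3cccc(F)c3)nc3ccc(F)cc23)cc1` reaches only the limit > 50000 nM in this assay, a limit of the measurement rather than a number.

Compound 1 and compound 2 lie within the scatter of each other, as a 1.0-fold lower number from compound 1 to compound 2 (0.00 log units; within the scatter) shows. Compound 3 sits at the limit of > 50000 nM in this assay, at which 1 of the 3 values shown sits, so for it only a floor is known. Compound 4 `Oc1ccccc1Nc1nc(-c2cccc(F)c2)nc2ccc(F)cc12` carries the change hydroxy in place of hydrogen on an aromatic carbon relative to compound 1. The nearest measured analogue of this change is the same group entering elsewhere on the same ring, in compound 3: an at least 1.0-fold higher number from compound 1 to compound 3 (0.01 log units; that floor lies within the scatter), a floor that lies within the scatter. The other changes on that ring, a 1.0-fold lower number from compound 1 to compound 2 (0.00 log units; within the scatter) and an at least 1.0-fold higher number from compound 2 to compound 3 (0.02 log units; that floor lies within the scatter), likewise stay within the scatter. Among the compounds with values here, no measured step therefore points to a change beyond the scatter in this assay for compound 4, and a value close to compound 1 is expected, with some chance that the measurement again returns only a limit. Compound 4 is expected near 48000 nM, between 24000 nM and 100000 nM. The expected step is a 1.0-fold higher number from compound 1 to compound 4 (0.00 log units; within the scatter).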

Compound 4, half-maximal inhibitory concentration: > 50000 nM
Compound 4 gave a limit, no number; the forecaster's own chance of this, stated with the estimate: 45%; middle value at least 1.0-fold (0.01 log units) from the limit.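

With compound 4, hydroxy on the anilino ring has been read in two forms, 2-hydroxyphenyl and 4-hydroxyphenyl, and in this assay compound 3 and compound 4 both end in a limit of the measurement and not a number: the limit of > 50000 nM in this assay, at which 2 of the 4 values shown sit.

The floors that can be read (an at least 1.0-fold higher number from compound 1 to compound 4 (0.01 log units; that floor lies within the scatter)) and (an at least 1.0-fold higher number from compound 2 to compound 4 (0.02 log units; that floor lies within the scatter)) both lie within the scatter, so neither form of the hydroxy group gives a step beyond it on this ring. The step between compound 3 and compound 4 cannot be read, since both values are limits.

Still open, as far as these compounds go, is whether any group on the anilino ring gives a number beyond the scatter of compound 1, for example an amine or a carboxylic acid in place of the hydroxy. From the compounds shown here alone, how far the true values of compound 3 and compound 4 lie past the limit also remains unknown.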